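Thiocarboximide series: removing the thiophenyl group from compound 2

The source may hold more compounds than are shown below. What is called first, only, known or untested is meant among the compounds shown, and "the series" means these compounds.

Three compounds carry numbers in a functional assay on the whole organism (stomach) for inhibition, with Rattus norvegicus as the target, at a dose of 100 mg/kg by the intraduodenal route; a lower number here means less inhibition, a higher number more inhibition at the dose given (going by the name of the read-out). Compound 1 `CC(Cn1ncccc1=O)C(=N)S` gives 40.3% in this assay. Compound 2 `N=C(S)CCn1nc(-c2cccs2)ccc1=O` gives 50.2% in this assay, and compound 3 `Cc1ccc(=O)n(CCC#N)n1`, which carries a nitrile on the chain in place of the thiocarboximide, gives 0.2% in this assay. Compound 2 and compound 1 lie within the scatter of each other, so nothing can be read into the gap between them; compound 3 sits well beyond the scatter below both, which points to the thiocarboximide as the part that carries the inhibition in this assay.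

Compound 4 `N=C(S)CCn1ncccc1=O` has not been measured. It differs from compound 2 in one place: hydrogen in place of thiophen-2-yl on an aromatic carbon. Among the measured compounds shown here, no step between two measured compounds isolates this change, so its size has to be guessed from compound 1, which also lacks the thiophen-2-yl and gives 40.3% in this assay. On that basis a small downward step is expected, of about a number 15.2 percentage points lower from compound 2 to compound 4 (beyond the scatter), not clearly beyond the scatter. For compound 4 the estimate in this assay is 35%, within a range of 15% to 55%.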

Compound 4, a percentage reported as inhibition, in the whole organism at one dose (the size of the read-out at that dose, not a potency): 28.8%
Estimate against measurement, compound 4: 6.2 percentage points above; measured number inside the range.
By their numbers in this assay, from the lowest: compound 3; then compound 4; then compounds 1 and 2 (each within the scatter of the next).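

In this assay, among the compounds shown here, the thiophen-2-yl on the aromatic carbon now has a step of its own: with hydrogen in its place there is a number 21.4 percentage points lower from compound 2 to compound 4 (beyond the scatter), so the group at this position bears on the read-out, which the earlier compounds could not show. The saturated chain carbon also has a step of its own: with hydrogen in place of methyl there is a number 11.5 percentage points lower from compound 1 to compound 4 (beyond the scatter), so each of the two groups, taken alone against compound 4, goes with a higher number at the dose given. Nothing available explains either step, and the mechanism behind them stays unaddressed.

Going by these compounds, whether thiophen-2-yl and methyl add up when both are present on the core of compound 4 stays open, as does what a phenyl on that aromatic carbon or an ethyl on that chain carbon would give. For the compounds shown here, compound 3 differs from compound 4 in more than one place, so the swap of thiocarboximide for nitrile still has no step of its own.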